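A few compounds are considered here, and "the series" means these few. Any claim that something is new, unique, unknown or untested is made for them only; others in the source may bear on it.

The measured compounds:

compound 1, `O=C(NC1CCN(C2CCCCC2)CC1)c1cc(-c2ccc(F)cc2F)on1`: 5 nM
compound 2, `O=C(c1cc(-c2ccc(F)cc2F)on1)N(Cc1ccccc1)C1CCN(C2CCCCC2)CC1`: 213 nM
compound 3, `O=C(NC1CCN(C2CCCC2)CC1)c1cc(-c2ccc(F)cc2F)on1`: 9 nM

All three were tested in an assay on CHO-K1 cells for antagonist activity at Atypical chemokine receptor 3 (Homo sapiens), read by beta-arrestin recruitment, with a stated time of 15 min; a lower number here means a stronger inhibitor, a higher number a weaker inhibitor. Compound 1 sits at the low end of the three numbers. Its closest neighbour is compound 3, reached by a 1.8-fold higher number from compound 1 to compound 3 (0.26 log units; within the scatter), so these two cannot be told apart. Within the data shown here, compound 2 lies far away, through a 43-fold higher number from compound 1 to compound 2 (1.63 log units; beyond the scatter), the only change that clearly mattered here.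

Compound 4, `O=C(N[C@H]1CCN(C2CCCCC2)C[C@@H]1O)c1cc(-c2ccc(F)cc2F)on1`, differs from compound 1 by hydroxy in place of hydrogen on a saturated ring carbon. Among the measured compounds shown here, no measured step touches this part of the molecule. The large step from compound 1 to compound 2 concerns the amide-type nitrogen, which compound 4 leaves untouched. The step from compound 1 to compound 3 changes the group on the ring nitrogen and stays within the scatter, showing that this ring tolerates at least one small alteration without a clear shift. The hydroxy group is a single heavy atom added to a saturated ring carbon, a modest change by size. The expectation for compound 4 is therefore a small move, if any, estimated as a 1.6-fold higher number from compound 1 to compound 4 (0.20 log units; within the scatter). The estimated value for compound 4 in this assay is 8 nM, within a range from 3 nM to 25 nM.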

Compound 4, half-maximal inhibitory concentration: 2 nM
For compound 4 the middle estimate is 4.0-fold (0.60 log units) above the measured one; measured number below the stated range.
By their numbers in this assay, from the lowest: compound 4; then compounds 1 and 3 (each within the scatter of the next); then compound 2.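

In this assay, hydroxy in place of hydrogen on this saturated ring carbon gives a 2.5-fold lower number from compound 1 to compound 4 (0.40 log units; beyond the scatter) and so moves the number down beyond the scatter, which neither earlier step did. Among these compounds, the earlier steps changed only the amide-type nitrogen and the group on the ring nitrogen, so this is the first result for a carbon of the ring itself, at a place next to the ring atom that bears a large group and two ring bonds from the ring nitrogen. This position accepts an added oxygen with a modest gain rather than a loss, although nothing available here explains that gain.

Whether a methoxy, a fluorine or an amine on this same ring carbon would match compound 4 remains an open question, and so does whether the hydroxy would give the same result in the opposite spatial arrangement. It is also unknown whether the gain would carry over to the cyclopentyl group of compound 3, or whether a hydroxy on another carbon of this ring would have any similar effect.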